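The source may report more compounds than this note shows. Statements on the series, on what has been measured and on what is new or still open speak of the compounds shown alone.

In an assay on isolated protein for inhibition of RAC-beta serine/threonine-protein kinase (Homo sapiens), read by mobility shift assay, tested at 30 uM (on this read-out lower numbers stand for less inhibition and higher numbers for more inhibition at the one concentration tested (going by the name of the read-out)), compound 1 `CC(C)(C)c1cc2nn(-c3ccccc3)c(N)c2c(=O)[nH]1` gives 3%. Compound 2 `Nc1c2c(=O)[nH]c(-c3ccccc3)cc2nn1-c1ccccc1` gives -1% in this assay, and the step of a number 4 percentage points lower from compound 1 to compound 2 (within the scatter) lies within the scatter, so compound 2 stands level with compound 1 and the two values cannot be told apart. Compound 3 `Nc1c2c(=O)[nH]c(-c3ccccc3)cc2nn1-c1ccccn1` differs from compound 2 by pyridin-2-yl in place of phenyl on an aromatic nitrogen. Within the data shown here, no measured step touches this change: the single known step, a number 4 percentage points lower from compound 1 to compound 2 (within the scatter), altered a different group at a different place and was itself within the scatter. With both measured values near zero, the expectation is a number 3 percentage points higher from compound 2 to compound 3 (within the scatter), no step beyond the scatter. Compound 3 is therefore estimated at 2%, in the range -10% to 14%.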

Compound 3, a percentage reported as inhibition, at one concentration (the size of the read-out at that concentration, not a potency): 0%
Estimate against measurement, compound 3: 2 percentage points above; the range from low to high includes it.
By their numbers in this assay, from the lowest: compounds 2, 3 and 1 (each within the scatter of the next).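

In this assay, among these compounds, the first change at this aromatic nitrogen, pyridin-2-yl in place of phenyl, gives a number 1 percentage points higher from compound 2 to compound 3 (within the scatter) and so no difference that can be read. Exchanging one ring carbon for nitrogen adds a hydrogen-bond acceptor to this group, yet the values of the two compounds cannot be told apart. No available evidence bears on this result. On these data alone, with every value so far close to zero, it remains open whether a smaller group such as methyl, or a ring carrying an amine or a carboxylic acid, would give measurable inhibition at this position.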